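The source may hold more compounds than are shown below. What is called first, only, known or untested is meant among the compounds shown, and "the series" means these compounds.

Compound 2 `CCCOc1ccc(C(=O)Nc2cccc(NCc3ccccc3)n2)cc1` carries a benzylamino group on the shared core. In an in vitro assay on HEK-tsA201 cells for antagonist activity at Neuronal acetylcholine receptor; alpha3/beta4 (Homo sapiens), read by fluorescence and calcium flux (on this read-out higher numbers stand for weaker inhibition and lower numbers for stronger inhibition), compound 2 gives only a limit, > 100000 nM. Its close relative compound 1 `CCCOc1ccc(C(=O)Nc2cccc(Nc3ccc(Cl)cc3)n2)cc1` has a 4-chlorophenyl group in the same place. In this assay compound 1 likewise reaches only a limit, > 100000 nM. For the measured compounds named here, the single measured step, a step that the two limits leave unreadable from compound 1 to compound 2, is therefore unreadable because both ends sit at the limit of > 100000 nM in this assay, at which 2 of the 2 values shown sit. Compound 3 `CCCOc1ccc(C(=O)Nc2cccc(N3CCCCC3)n2)cc1` takes the change (piperidin-1-yl in place of benzylamino on an aromatic carbon). Going by the values given here, no measured step speaks to this exchange, and the starting point is itself a limit, so nothing so far points toward inhibition strong enough to register. Compound 3 is therefore expected to give 100000 nM, with a range from 30000 nM to 300000 nM. Most probably the result will again be reported only as a limit. This corresponds to an expected step of a number no higher from compound 2 to compound 3 (the limit leaves the size open).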

Compound 3, half-maximal inhibitory concentration: > 100000 nM
Compound 3 ended at the assay's limit; the forecaster's own chance of this, stated with the estimate: 80%; the middle value lies on the limit itself.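

Compound 3 also stops at a limit, so the steps linking compound 1, compound 2 and compound 3 cannot be read, and none of their groups can be ranked: the limit of > 100000 nM in this assay, at which 3 of the 3 values shown sit. The compounds shown leave open which change on the shared core, if any, would give a measurable inhibition in this assay.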